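The source may hold more compounds than are shown below. What is called first, only, known or untested is meant among the compounds shown, and "the series" means these compounds.

The measured compounds:

Compound 1, `COc1ccc(/C=C/c2cc(OC)cc(OC)c2/C=C/C(=O)NC2CC2)cc1`: in a functional assay on A549 cells (Homo sapiens) for inhibition, read by MTT assay, with a stated time of 48 h (a higher number here means a weaker inhibitor, a lower number a stronger inhibitor), compound 1 gives 8810 nM.
Compound 2, `COc1ccc(/C=C/c2cc(OC)cc(OC)c2/C=C/C(=O)N2CCCCC2C)cc1`: in this assay compound 2 gives 5770 nM.

Within the data shown here, on these two numbers compound 2 stands lowest, but the gap to compound 1 is small: the one measured step, a 1.5-fold lower number from compound 1 to compound 2 (0.18 log units; within the scatter), lies within the scatter, so the two compounds cannot be told apart by potency. Compound 3, `CCCCCCNC(=O)/C=C/c1c(/C=C/c2ccc(OC)cc2)cc(OC)cc1OC`, has not yet been measured. It differs from compound 2 at the carbonyl carbon: hexylamino in place of 2-methylpiperidin-1-yl on a carbonyl carbon. Among the measured compounds shown here, only one step bears on this change, since the shift from cyclopropylamino to 2-methylpiperidin-1-yl at the same carbonyl carbon is the sole measured exchange of the amide substituent, and it moved the number by a 1.5-fold lower number from compound 1 to compound 2 (0.18 log units; within the scatter), no more than scatter. The hexylamino group returns a hydrogen-bond donor, as cyclopropylamino had, but nothing here shows that such a change shifts the number beyond the scatter. For compound 3 the expected step is therefore a 1.1-fold higher number from compound 2 to compound 3 (0.05 log units; within the scatter), essentially none beyond the scatter. Compound 3 is estimated at 6500 nM, between 2500 nM and 17000 nM.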

Compound 3, half-maximal inhibitory concentration: 6230 nM
Estimate against measurement, compound 3: 1.0-fold (0.02 log units) above, and the stated range covers the measured number.
By their numbers in this assay, from the lowest: compounds 2, 3 and 1 (each within the scatter of the next).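

In this assay the open hexylamino chain takes the place of the 2-methylpiperidin-1-yl ring on the carbonyl carbon, and the result is a 1.1-fold higher number from compound 2 to compound 3 (0.03 log units; within the scatter) so neither the loss of the ring nor the entry of a hydrogen-bond donor separates these two compounds. The comparison with the other secondary amide points the same way: hexyl in place of cyclopropyl on the amide-type nitrogen gives a 1.4-fold lower number from compound 1 to compound 3 (0.15 log units; within the scatter) and so a long open chain and a cyclopropyl group cannot be told apart there either. Across cyclopropylamino, 2-methylpiperidin-1-yl and hexylamino, then, no step at this carbonyl carbon goes beyond the scatter, and nothing available accounts for this lack of change.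

The compounds shown carry only carbon substituents on the amide nitrogen, so they leave open whether a hexyl chain ending in an amine or a carboxylic acid would move the number beyond the scatter. They also leave open what a benzyl group or a morpholine ring on that nitrogen would do, and whether any change at this position can matter on the shared core.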